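Swapping the Aryl Group of Compound 3

A few compounds are considered here, and "the series" means these few. Any claim that something is new, unique, unknown or untested is made for them only; others in the source may bear on it.

Of the compounds shown here, three sharing one core have been measured in a functional assay on B16 cells (Mus musculus) for cytotoxicity, read by CCK-8 assay, with a stated time of 24 h; a higher number here means a weaker inhibitor, a lower number a stronger inhibitor. Compound 1 `COc1cccc(-c2nc(N)c(Oc3ccccc3OC)c(Cl)n2)c1` gives 23600 nM, compound 2 `COc1ccccc1Oc1c(N)nc(-c2ccccc2F)nc1Cl` gives 13800 nM, and compound 3 `COc1ccccc1Oc1c(N)nc(-c2ccccc2F)nc1OCCO` gives 11800 nM. The value for compound 3 lies within the usual scatter of both others, so these measurements do not separate the three compounds.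

Compound 4 `COc1ccccc1Oc1c(N)nc(-c2ccc(I)cc2)nc1OCCO` differs from compound 3 in one place, on an aromatic carbon between two ring nitrogen atoms, where 4-iodophenyl stands in place of 2-fluorophenyl (4-iodophenyl in place of 2-fluorophenyl on an aromatic carbon).

The closest guide is a change at that same place, with 2-fluorophenyl in place of 3-methoxyphenyl: a 1.7-fold lower number from compound 1 to compound 2 (0.23 log units; within the scatter). The other measured change, 2-hydroxyethoxy in place of chloro, lies elsewhere on the core: a 1.2-fold lower number from compound 2 to compound 3 (0.07 log units; within the scatter). Neither step goes beyond the scatter, so no step beyond the scatter is expected in this assay, and no direction can be firmly expected. Among the measured compounds shown here, no measured compound carries 4-iodophenyl, however, so the range must stay wide. The expected change is a 1.2-fold lower number from compound 3 to compound 4 (0.07 log units; within the scatter). For compound 4 the estimated value is 10000 nM, with an expected range from 4000 nM to 25000 nM.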

Compound 4, half-maximal inhibitory concentration: 19600 nM
For compound 4 the middle estimate is 2.0-fold (0.29 log units) below the measured one; the measured number falls inside the stated range.
By their numbers in this assay, from the lowest: compounds 3, 2, 4 and 1 (each within the scatter of the next).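

At the aromatic carbon between two ring nitrogen atoms, 4-iodophenyl in place of 2-fluorophenyl gives a result in this assay that stays close to that of compound 3 (a 1.7-fold higher number from compound 3 to compound 4 (0.22 log units; within the scatter)). The new group has the same count of heavy atoms as the old one but carries iodine instead of fluorine, and this exchange of aryl groups, like the earlier one at the same place (a 1.7-fold lower number from compound 1 to compound 2 (0.23 log units; within the scatter)), stays within the scatter, so neither step shows that the aryl group at this position matters in this assay. No measured property of these groups bears on this result, so nothing can be said about the reason for it.

From the compounds shown here alone, it remains open whether any group at this position can move the number beyond the scatter, for instance a phenyl ring carrying a carboxylic acid, or a saturated amine such as piperidine in place of the aryl ring. Going by these compounds, it is also open whether the 4-iodophenyl result would hold with chloro, or with a longer chain such as 3-hydroxypropoxy, in place of 2-hydroxyethoxy.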